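The source may hold more compounds than are shown below. What is called first, only, known or untested is meant among the compounds shown, and "the series" means these compounds.

Three measured compounds share one core and differ only in the group on an aromatic carbon of a six-membered aromatic ring of carbon only. Compound 1 `COc1ccc(/C=N/NC(=O)CSc2nnc(-c3ccncc3)n2-c2ccccc2)cc1` carries a methoxy group there, and in a functional assay on HepG2 cells (Homo sapiens) for inhibition, read by MTT assay, with a stated time of 48 h (a lower number here means a stronger inhibitor, a higher number a weaker inhibitor), compound 1 gives 27100 nM. Compound 2 `O=C(CSc1nnc(-c2ccncc2)n1-c1ccccc1)N/N=C/c1ccc(Br)cc1` carries a bromo group, and in this assay compound 2 gives 5990 nM. Compound 3 `O=C(CSc1nnc(-c2ccncc2)n1-c1ccccc1)N/N=C/c1ccc(Cl)cc1` carries a chloro group, and in this assay compound 3 gives 11000 nM. Among these three numbers compound 3 stands second highest: the step of a 1.8-fold higher number from compound 2 to compound 3 (0.26 log units; within the scatter) is within the scatter, whereas a 2.5-fold lower number from compound 1 to compound 3 (0.39 log units; beyond the scatter) is beyond it.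

Compound 4 `O=C(CSc1nnc(-c2ccncc2)n1-c1ccccc1)N/N=C/c1ccc(F)cc1` differs from compound 3 by fluoro in place of chloro on an aromatic carbon. Within the data shown here, the steps that bear on this are the halogen-for-methoxy exchanges, a 4.5-fold lower number from compound 1 to compound 2 (0.66 log units; beyond the scatter) and a 2.5-fold lower number from compound 1 to compound 3 (0.39 log units; beyond the scatter), both modest, and the one halogen-for-halogen exchange, a 1.8-fold higher number from compound 2 to compound 3 (0.26 log units; within the scatter), which stayed within the scatter. Among the measured compounds shown here, since the only exchange of one halogen for another gave no step beyond the scatter, the move to compound 4 is expected to be a 1.4-fold higher number from compound 3 to compound 4 (0.13 log units; within the scatter), likewise within the scatter. In this assay compound 4 is therefore estimated at 15000 nM, with a range from 6000 nM to 40000 nM.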

Compound 4, half-maximal inhibitory concentration: 9330 nM
Compound 4: the middle estimate sits 1.6-fold (0.21 log units) above what was measured; low and high end bracket the measured number.
By their numbers in this assay, from the lowest: compounds 2, 4 and 3 (each within the scatter of the next); then compound 1.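

With fluoro in place, all three halogens can be compared at this position, and in this assay none can be told from another: a 1.2-fold lower number from compound 3 to compound 4 (0.07 log units; within the scatter) and a 1.6-fold higher number from compound 2 to compound 4 (0.19 log units; within the scatter) both fall within the scatter, as did the earlier exchange of bromo for chloro. Fluoro also separates from methoxy, with a 2.9-fold lower number from compound 1 to compound 4 (0.46 log units; beyond the scatter), so compound 1 now stands apart from all three halogen compounds, its step to each lying beyond the scatter and its number the highest. On this aromatic carbon, then, the choice among bromo, chloro and fluoro makes no difference that this assay can resolve, while replacing methoxy with any one of them does lower the number, though only modestly.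

From the compounds shown here alone, it remains open whether a plain hydrogen, a methyl, a nitrile, an amine or a carboxylic acid on this same carbon would group with the halogens, with methoxy, or apart from both. Nothing available here explains why methoxy differs from the three halogens.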